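A Methyl Removed from a Compound at the Assay Limit

This account rests on a few compounds, and the source may have more. Where it says the series, first, only, none or still open, it means among the compounds named here.

Compound 1 `CC(C)(C)OC(=O)N1CCN(C(=S)SCc2cn(Cc3ccc(Cl)cc3)nn2)CC1`: > 128000 nM
Compound 2 `Cc1cc(=O)oc2cc(OCCn3cc(CSC(=S)N4CCN(C(=O)OC(C)(C)C)CC4)nn3)ccc12`: > 128000 nM
Compound 3 `S=C(SCc1cn(Cc2ccccc2Cl)nn1)N1CCNCC1`: > 128000 nM

These three compounds were tested in a functional assay on ECa-109 cells (Homo sapiens) for inhibition, read by MTT assay, with a stated time of 72 h; on this read-out lower numbers stand for stronger inhibition and higher numbers for weaker inhibition. The value of compound 2 in this assay, > 128000 nM, is a limit of the assay and not a number. The same holds for compound 1 with > 128000 nM. Compound 3 likewise gives > 128000 nM, a limit. Going by the values given here, compound 2 therefore stands nowhere in particular on a scale of numbers: the evidence is only (the limit of > 128000 nM in this assay, at which 3 of the 3 values shown sit), so no compound can be set above or below another, and no step between any two of them can be measured.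

Compound 4 `CC(C)(C)OC(=O)N1CCN(C(=S)SCc2cn(CCOc3ccc4ccc(=O)oc4c3)nn2)CC1` has not yet been tested in this assay. It differs from compound 2 in one place: hydrogen in place of methyl on an aromatic carbon. The change is small, leaving the rest of the shared core untouched. With every measured compound sitting at the same limit, there is no step to build on, and a change of a single carbon gives no reason to expect a shift beyond the scatter in either direction. Compound 4 is therefore expected to show a step that the limit leaves unreadable from compound 2 to compound 4, that is, to remain at the limit. For compound 4 the estimate is 200000 nM, with a range of 100000 nM to 500000 nM.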

Compound 4, half-maximal inhibitory concentration: > 128000 nM
Compound 4 ended at the assay's limit; the forecaster's own chance of this, stated with the estimate: 85%; the middle value lies beyond the limit too.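

Going by these compounds alone, compound 2 and compound 4 both end at a limit of the assay, not at a number, and no step between them can be read. The compounds shown leave open whether any change to the shared core would give a measurable value in this assay, and all of them rest at one limit: the limit of > 128000 nM in this assay, at which 4 of the 4 values shown sit.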